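Same Exchange on the Shared Core, Applied a Second Time

This account rests on a few compounds, and the source may have more. Where it says the series, first, only, none or still open, it means among the compounds named here.

Measured compounds:
compound 1 `C=C1[C@@H](OC(C)=O)C[C@@H]2[C@](C)(COC=O)[C@H](OC(C)=O)CC[C@@]2(C)[C@@H]1C[C@@H](Nc1cccc(F)c1)C1=CCOC1=O` — 14100 nM
compound 2 `C=C1[C@@H](OC(C)=O)C[C@@H]2[C@](C)(COC=O)[C@H](OC(C)=O)CC[C@@]2(C)[C@@H]1C/C=C1/C(=O)OC[C@H]1OC(C)=O` — 12900 nM
compound 3 `C=C1[C@@H](OC(C)=O)C[C@@H]2[C@](C)(CO[Si](C)(C)C(C)(C)C)[C@H](OC(C)=O)CC[C@@]2(C)[C@@H]1C[C@@H](Nc1cccc(F)c1)C1=CCOC1=O` — 3820 nM

Three compounds were tested in a functional assay on MCF7 cells (Homo sapiens) for cytotoxicity, read by sulforhodamine B assay (a higher number here means a weaker inhibitor, a lower number a stronger inhibitor), and a fourth, compound 4 `C=C1[C@@H](OC(C)=O)C[C@@H]2[C@](C)(CO[Si](C)(C)C(C)(C)C)[C@H](OC(C)=O)CC[C@@]2(C)[C@@H]1C/C=C1/C(=O)OC[C@H]1OC(C)=O`, is not yet measured. In this assay compound 1 gives 14100 nM and compound 2 gives 12900 nM, two numbers that lie within the scatter of each other. The difference between the cores of compound 1 and compound 2 is not broken down here.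

Compound 3 differs from compound 1 by a group of 7 heavy atoms (6 carbon, 1 silicon; no ring) in place of a group of 2 heavy atoms (1 carbon, 1 oxygen; no ring), on an oxygen on a saturated carbon, and this exchange produced a 3.7-fold lower number from compound 1 to compound 3 (0.57 log units; beyond the scatter), a modest step beyond the scatter. The pair compound 2 and compound 4 is built in exactly the same way: compound 4 differs from compound 2 by a group of 7 heavy atoms (6 carbon, 1 silicon; no ring) in place of a group of 2 heavy atoms (1 carbon, 1 oxygen; no ring), on an oxygen on a saturated carbon, at a place described in the same words. So the change is the same, made at the same kind of position on the shared core, and it occurs twice among the four compounds.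

The expectation for compound 4 rests on compound 1 and compound 3, because a 3.7-fold lower number from compound 1 to compound 3 (0.57 log units; beyond the scatter) was obtained from this very exchange. The step expected from compound 2 to compound 4 is therefore a 3.7-fold lower number from compound 2 to compound 4 (0.57 log units; beyond the scatter). On that basis compound 4 is estimated at 3500 nM, with the estimate spanning from 1500 nM to 8500 nM.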

Compound 4, half-maximal inhibitory concentration: 4540 nM
For compound 4 the middle estimate is 1.3-fold (0.11 log units) below the measured one, and the stated range covers the measured number.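

In this assay, putting the group of 7 heavy atoms (6 carbon, 1 silicon) in place of the formyl group, on an oxygen on a saturated carbon, gave a 2.8-fold lower number from compound 2 to compound 4 (0.45 log units; beyond the scatter) and so moved the number in the same direction as on the core of compound 1. The size of the step also carried over from one core to the other, as the two steps do not differ beyond what repeated measurements would allow: the same change on two cores in this assay, a 3.7-fold lower number (0.57 log units; beyond the scatter) from compound 1 to compound 3 and a 2.8-fold lower number (0.45 log units; beyond the scatter) from compound 2 to compound 4, 1.3-fold (0.11 log units) apart, within the scatter of two such steps. This shows that the exchange transferred between these two cores in this one cytotoxicity read-out, but two pairs are too few to establish a rule for the series, and the numbers do not show why the exchange lowers the value or whether it would do so on any further core or in another cell line.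

The compounds shown leave open what other groups on the same oxygen would do, such as a free hydroxyl, a methyl or a benzyl, and whether the number follows the size of the group or something specific to the silicon-bearing group. They also leave open whether the step would hold on a core carrying a different substituent in place of the 3-fluoroanilino group, such as a simple alkyl amine.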